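The source may report more compounds than this note shows. Statements on the series, on what has been measured and on what is new or still open speak of the compounds shown alone.

Compounds measured so far:
- Compound 1, `Cc1cnc(Nc2ccc(Cl)cc2)nc1Nc1nc2ccccc2s1`, in a functional assay on MCF7 cells (Homo sapiens) for antiproliferative activity, read by MTT assay, with a stated time of 48 h (on this read-out higher numbers stand for weaker inhibition and lower numbers for stronger inhibition), gives only a limit of the assay, > 50000 nM.
- Compound 2, `Cc1cnc(Nc2ccc([N+](=O)[O-])cc2)nc1Nc1nc2ccccc2s1`, in this assay gives only a limit, > 50000 nM.
- Compound 3, `COc1ccc(Nc2ncc(C)c(Nc3nc4ccccc4s3)n2)cc1`, in this assay gives only a limit, > 50000 nM.

Compound 3 therefore stands where all three measured compounds stand: at the limit of the assay, with no number of its own. The three shown values all sit at the limit of > 50000 nM in this assay, at which 3 of the 3 values shown sit.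

Compound 4, `COc1cccc(Nc2ncc(C)c(Nc3nc4ccccc4s3)n2)c1`, differs from compound 3 in one place: 3-methoxyphenyl in place of 4-methoxyphenyl on a nitrogen on an aromatic ring.

The measured steps that bear on this change are a step that the two limits leave unreadable from compound 1 to compound 3 and a step that the two limits leave unreadable from compound 2 to compound 3, both of which involve the 4-methoxyphenyl group of compound 3, and a step that the two limits leave unreadable from compound 1 to compound 2; each of these is left unreadable by the two limits, so their sizes are not known. Within the data shown here, no measured step moves a 4-methoxyphenyl to a 3-methoxyphenyl, and no measured compound carries a 3-methoxyphenyl. The data give no reason to expect a readable step in this assay in either direction.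

For compound 4 the expected value in this assay is 50000 nM, with a range from 15000 nM to 200000 nM. The step this estimate means, a number no higher from compound 3 to compound 4 (the limit leaves the size open), is expected to be none beyond the scatter, and the result is expected most likely to be again only a limit.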

Compound 4, half-maximal inhibitory concentration: > 50000 nM
Compound 4: only a limit was reported; the forecaster's own chance of this, stated with the estimate: 75%; the middle value lies on the limit itself.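

Compound 4 also gives only a limit in this assay, so none of its steps from compound 1, compound 2 or compound 3 can be read: the limit of > 50000 nM in this assay, at which 4 of the 4 values shown sit.

The compounds shown leave open whether changing the aryl group on this nitrogen affects antiproliferative activity at all.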